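Isopropyl for 4-fluorophenyl on the ring amide nitrogen

A few compounds are considered here, and "the series" means these few. Any claim that something is new, unique, unknown or untested is made for them only; others in the source may bear on it.

Measured compounds:
compound 1 `COc1ncc(-c2ccc3c(c2)N(c2ccc(F)cc2)C(=O)CO3)cc1NS(=O)(=O)c1ccc(F)cc1` — > 40000 nM
compound 2 `CC(C)N1C(=O)COc2ccc(-c3cccc(NS(=O)(=O)c4ccc(F)cc4)c3)cc21` — 22600 nM

Compound 1 is the starting point of this step. In a functional assay on HCT-116 cells (Homo sapiens) for antiproliferative activity, read by MTT assay, with a stated time of 72 h (a higher number here means a weaker inhibitor, a lower number a stronger inhibitor), compound 1 gives only a limit, > 40000 nM, which is the edge of the assay and not a number. In this assay, within the data shown here, compound 2 gives 22600 nM; no step between compound 1 and compound 2 is worked out, so only the two values themselves are on hand.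

The compound not yet measured is compound 3 `COc1ncc(-c2ccc3c(c2)N(C(C)C)C(=O)CO3)cc1NS(=O)(=O)c1ccc(F)cc1`. It differs from compound 1 in one place: isopropyl in place of 4-fluorophenyl on an amide-type nitrogen in a ring. Compound 2 carries the same isopropyl on its amide-type nitrogen and comes in at a measurable, if weak, value, so compound 3 is expected to sit in the weak range and may or may not fall under the limit.

For compound 3 a step of an at least 1.3-fold lower number from compound 1 to compound 3 (0.12 log units; that floor lies within the scatter) is expected in this assay, small and within the scatter at best, since compound 1 shows only the limit (the limit of > 40000 nM in this assay, at which 1 of the 2 values shown sits). The estimate for compound 3 in this assay is 30000 nM, with a range from 8000 nM to 80000 nM.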

Compound 3, half-maximal inhibitory concentration: 19200 nM
Estimate against measurement, compound 3: 1.6-fold (0.19 log units) above; the measured number falls inside the stated range.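

In this assay, isopropyl in place of 4-fluorophenyl on the amide-type nitrogen in the ring gives an at least 2.0-fold lower number from compound 1 to compound 3 (0.31 log units; beyond the scatter). On the core of compound 1, the isopropyl analogue compound 3 gives a true number, 19200 nM, which shows that this nitrogen does not need an aromatic ring for a readable value, although the activity remains weak. This step can be read only as a floor, and its true size stays unknown: the limit of > 40000 nM in this assay, at which 1 of the 3 values shown sits.

The compounds shown leave open how the number responds to other groups on this nitrogen, such as methyl, cyclopropyl, a longer chain like n-butyl, or a chain ending in an amine or a carboxylic acid. With only the 4-fluorophenyl and isopropyl pair on this core, the step cannot be assigned to the loss of the aromatic ring, the loss of the fluorine or the smaller group as a whole, and a benzyl or an unsubstituted phenyl group would be needed to separate these readings.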